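Two boron-containing compounds and a proposed aminopropyl analogue

The compounds below may be only part of what the source reports. "The series", "measured", "known", "first", "only" and "open" are said of these compounds alone.

Compound 1 `OB1OCc2ccc(-n3cc(Sc4ccc5ccccc5c4)c4ccccc43)cc21` and compound 2 `O=C(c1ccccc1)c1ccn(-c2ccc3c(c2)B(O)OC3)c1` have both been examined in an ADME assay on L929 cells (Mus musculus) for cytotoxicity, read by resazurin assay, with a stated time of 72 h; a higher number here means a weaker inhibitor, a lower number a stronger inhibitor. Compound 1 returns only a limit, > 10 ug/mL. Compound 2 likewise returns only a limit, > 10 ug/mL. Both values sit at the limit of > 10 ug/mL in this assay, at which 2 of the 2 values shown sit, so compound 2 stands at a limit of the assay and not at a number, and nothing shown separates it from compound 1. Compound 3 `NCCCC(=O)c1ccn(-c2ccc3c(c2)B(O)OC3)c1` has not yet been measured in this assay. It differs from compound 2 at one place: 3-aminopropyl in place of phenyl on a carbonyl carbon. Among the measured compounds shown here, no step between measured compounds is known here, so the size of this change cannot be read from another pair. Compound 3 is expected to give 30 ug/mL, with a range from 10 ug/mL to 100 ug/mL. The step that the limit leaves unreadable from compound 2 to compound 3 that this estimate implies is expected to be none beyond the scatter, most likely with another limit reported.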

Compound 3, half-maximal inhibitory concentration: > 10 ug/mL
Compound 3: a limit, no number; the forecaster's own chance of this, stated with the estimate: 80%; the middle value does not contradict the limit.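

Compound 2 and compound 3 both stand at a limit of the assay and not at a number, so no step between them can be read: the limit of > 10 ug/mL in this assay, at which 3 of the 3 values shown sit.

The compounds shown leave open whether 3-aminopropyl in place of phenyl on a carbonyl carbon changes the read-out in this assay at all.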